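The source may hold more compounds than are shown below. What is called first, only, known or untested is meant among the compounds shown, and "the series" means these compounds.

- compound 1 `CC1(/C=C/c2ccccc2)C=CC(=O)O1`: 123000 nM
- compound 2 `CC1(/C=C/c2ccccc2C(F)(F)F)C=CC(=O)O1`: 15800 nM

Among the measured compounds shown here, in a functional assay on HT-29 cells (Homo sapiens) for inhibition, read by sulforhodamine B assay, with a stated time of 48 h (on this read-out higher numbers stand for weaker inhibition of growth and lower numbers for stronger inhibition of growth), compound 1 gives 123000 nM, the higher of the two numbers measured so far, so it shows the weaker inhibition of growth. Compound 3 `CC1(/C=C/c2ccc(C(F)(F)F)cc2)C=CC(=O)O1` has not yet been measured. It differs from compound 1 by trifluoromethyl in place of hydrogen on an aromatic carbon. For the measured compounds named here, the one measured step that bears on this change is a 7.8-fold lower number from compound 1 to compound 2 (0.89 log units; beyond the scatter), the same replacement of hydrogen by trifluoromethyl made on a different aromatic carbon. A modest step towards a lower number is therefore expected in this assay, of similar or somewhat smaller size, although a single step says little about how much the place of the group matters. The estimated change is a 4.9-fold lower number from compound 1 to compound 3 (0.69 log units; beyond the scatter). For compound 3 the expected value is 25000 nM, with an estimated range from 8000 nM to 80000 nM.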

Compound 3, concentration for total growth inhibition: 12300 nM
Compound 3: the middle estimate sits 2.0-fold (0.31 log units) above what was measured; low and high end bracket the measured number.
By their numbers in this assay, from the lowest: compounds 3 and 2 (each within the scatter of the next); then compound 1.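

In this assay, trifluoromethyl in place of hydrogen on the aromatic carbon para to a group of 9 heavy atoms brings a 10-fold lower number from compound 1 to compound 3 (1.00 log units; beyond the scatter) and so shows that the lower number seen earlier is not confined to one aromatic carbon. Compound 2, which carries the same group on a different aromatic carbon, gives 15800 nM and compound 3 gives 12300 nM in this assay and these two numbers lie within the scatter of each other, so the two places are not told apart here. Nothing measured here accounts for the lower numbers.

As far as these compounds go, it remains open whether a methoxy group, a nitrile or a carboxylic acid on the same aromatic carbon would also lower the number. Also open, from the compounds shown here alone, is whether trifluoromethyl would do so on the remaining aromatic carbons of the ring.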